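This account rests on a few compounds, and the source may have more. Where it says the series, first, only, none or still open, it means among the compounds named here.

In a functional assay on HL-60 cells (Homo sapiens) for inhibition, read by MTT assay, with a stated time of 72 h (a higher number here means a weaker inhibitor, a lower number a stronger inhibitor), compound 1 (`C=C(C)c1ccc(N2CCN(C(=O)c3oc(C)nc3-c3ccccc3)CC2)cc1`) gives "not active" (no number reported) with no number reported. Compound 2 (`Cc1nc(-c2ccccc2)c(C(=O)N2CCN(c3ccccc3Cl)CC2)o1`) gives 124 nM and compound 3 (`CC(=O)Nc1cccc(N2CCN(C(=O)c3oc(C)nc3-c3ccccc3)CC2)c1`) gives 329 nM as the higher of the two numbers. Compound 4 (`Cc1nc(-c2ccccc2)c(C(=O)N2CCN(c3cccc(F)c3)CC2)o1`) differs from compound 3 by fluoro in place of acetamido on an aromatic carbon with fluoro in place of acetamido on an aromatic carbon, meta to a large group. Within the data shown here, the one measured step bearing on this is a 2.7-fold higher number from compound 2 to compound 3 (0.42 log units; beyond the scatter) and it was modest, so a step of similar size toward a lower number is expected, though no measured compound carries fluoro. The estimate means a step (a 1.6-fold lower number from compound 3 to compound 4 (0.22 log units; within the scatter)) of modest size. In this assay compound 4 is estimated at 200 nM (range 70 nM to 600 nM).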

Compound 4, half-maximal inhibitory concentration: 45 nM
For compound 4 the middle estimate is 4.4-fold (0.65 log units) above the measured one; the whole stated range lies above it.
By their numbers in this assay, from the lowest: compound 4; then compound 2; then compound 3.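

In this assay, fluoro in place of acetamido on this aromatic carbon gives a 7.3-fold lower number from compound 3 to compound 4 (0.86 log units; beyond the scatter), a far larger step than the one that separated the two earlier numbers. The 3-fluorophenyl group in place of 2-chlorophenyl gives a 2.8-fold lower number from compound 2 to compound 4 (0.44 log units; beyond the scatter), so compound 4 now holds the lowest number of the three compounds with numbers. No measurement shown explains either step. Going by these compounds, whether chloro, methoxy or an amino group on this same aromatic carbon would match fluoro remains open.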